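The source may hold more compounds than are shown below. What is called first, only, known or untested is meant among the compounds shown, and "the series" means these compounds.

The shared core of these compounds is tested in an assay on isolated protein for inhibition of Fatty-acid amide hydrolase 1 (Homo sapiens), read by fluorescence, with a stated time of 30 min; a higher number here means a weaker inhibitor, a lower number a stronger inhibitor. Compound 1 `CCOC(=O)c1cc(-c2cccc(OC(=O)NC3CCCCC3)c2)n(Cc2ccccc2)n1` gives 70 nM. Compound 2 `NC(=O)c1cc(-c2cccc(OC(=O)NC3CCCCC3)c2)n(-c2ccc(Cl)cc2)n1` gives 174 nM in this assay. Compound 3 `CCOC(=O)c1cc(-c2cccc(OC(=O)NC3CCCCC3)c2)nn1CC` gives 507 nM, the highest of the three numbers and therefore the weakest inhibitor shown here; its gap to compound 2, and its wider gap to compound 1, both lie beyond the usual scatter. Compound 4 `CCOC(=O)c1cc(-c2cccc(OC(=O)NC3CCCCC3)c2)nn1-c1ccc(OC)cc1` has not yet been measured. It differs from compound 3 in one place: 4-methoxyphenyl in place of ethyl on an aromatic nitrogen. Among the measured compounds shown here, no pair of measured compounds differs in just this way, so the step cannot be read off directly. Still, compound 1 and compound 2, each carrying a ring on that aromatic nitrogen, give the two lower numbers, while compound 3 with its ethyl gives the highest. On that basis the number for compound 4 is expected to fall below that of its parent. The expected step is a 3.4-fold lower number from compound 3 to compound 4 (0.53 log units; beyond the scatter), large enough to pass beyond the scatter. In this assay compound 4 is estimated at 150 nM, with a range from 50 nM to 450 nM.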

Compound 4, half-maximal inhibitory concentration: 407 nM
For compound 4 the middle estimate is 2.7-fold (0.43 log units) below the measured one; the range from low to high includes it.
By their numbers in this assay, from the lowest: compound 1; then compound 2; then compounds 4 and 3 (each within the scatter of the next).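

In this assay, putting 4-methoxyphenyl in place of ethyl on the aromatic nitrogen next to the ring atom that bears an ethoxycarbonyl group gives a 1.2-fold lower number from compound 3 to compound 4 (0.10 log units; within the scatter). At this position, then, a six-membered aromatic ring carrying a methoxy group can stand in for a short ethyl chain without a shift beyond the scatter, and a ring on this nitrogen does not by itself bring the number down in this pair. No measurement is available to explain this result.

The compounds shown leave open whether a plain phenyl ring or a longer chain such as butyl on this nitrogen would move the number beyond the scatter. Also open, on these data alone, is whether the same swap would give a similar result with a carboxylic acid in place of the ethoxycarbonyl group.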